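Cyclopentyl Ester Follows Thioester in Adenosine Receptor Series

A few compounds are considered here, and "the series" means these few. Any claim that something is new, unique, unknown or untested is made for them only; others in the source may bear on it.

Of the compounds shown here, three built on a shared core have been measured in an assay on membranes from CHO cells for displacement of a labelled ligand from adenosine receptor A1 (Homo sapiens), read by scintillation counting, with a stated time of 60 min, tested at 1 uM; on this read-out lower numbers stand for less inhibition and higher numbers for more inhibition at the one concentration tested (going by the name of the read-out). Compound 1 `CC1=C(C(=O)OC(C)(C)C)C(c2ccsc2)NC(=O)N1` gives 15%. Compound 2 `CC1=C(C(=O)CC(C)C)C(c2ccsc2)NC(=O)N1` gives 37%, and compound 3 `CC1=C(C(=O)SC(C)C)C(c2ccsc2)NC(=O)N1` gives 24%. Among these three numbers compound 3 stands second highest: the step of a number 9 percentage points higher from compound 1 to compound 3 (within the scatter) lies within the scatter, whereas the step of a number 13 percentage points lower from compound 2 to compound 3 (beyond the scatter) is beyond it, as is the step of a number 22 percentage points higher from compound 1 to compound 2 (beyond the scatter).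

Compound 4 `CC1=C(C(=O)OC2CCCC2)C(c2ccsc2)NC(=O)N1` differs from compound 3 in one place: cyclopentyloxy in place of isopropylsulfanyl on a carbonyl carbon. Compound 4 thus resembles compound 1 in having an oxygen, rather than a sulfur or a carbon, attached to the carbonyl carbon. Among the measured compounds shown here, the step that bears most directly on this change is the one from compound 1 to compound 3, which swapped tert-butoxy for isopropylsulfanyl and stayed within the scatter; the step from compound 2 to compound 3 was modest but beyond it. Returning from isopropylsulfanyl to an oxygen-attached group is therefore expected to move the number little, so compound 4 is expected to show a number 4 percentage points lower from compound 3 to compound 4 (within the scatter), a change within the scatter and, if anything, slightly downward. Compound 4 is estimated at 20%, with a range from 5% to 38% in this assay.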

Compound 4, a percentage reported as inhibition, at one concentration (the size of the read-out at that concentration, not a potency): 5%
Compound 4: middle estimate off by 15 percentage points, on the high side, within the range that was stated.
By their numbers in this assay, from the lowest: compounds 4, 1 and 3 (each within the scatter of the next, the first and the last beyond it); then compound 2.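

In this assay, the exchange of isopropylsulfanyl for cyclopentyloxy on the carbonyl carbon gives a number 19 percentage points lower from compound 3 to compound 4 (beyond the scatter), so a thioester and an ester at this position can now be told apart, which compound 1 and compound 3 could not show because they lie within the scatter of each other. The two groups attached through oxygen stay together, with a number 10 percentage points lower from compound 1 to compound 4 (within the scatter), so exchanging tert-butyl for cyclopentyl on that oxygen, and thereby bringing in a five-membered ring, is not resolved by this read-out. Against the isobutyl ketone the gap reaches a number 32 percentage points lower from compound 2 to compound 4 (beyond the scatter), the widest step in the series so far, and compound 2 now stands apart from both esters, compound 1 and compound 4.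

Nothing at hand explains any of these differences. Going by these compounds, it remains open how a nitrogen-attached group, such as a secondary amine forming an amide on the carbonyl carbon, or a longer straight chain in place of isobutyl would fall relative to these numbers.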